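Swapping the five-membered ring on a fused agonist core

The source may report more compounds than this note shows. Statements on the series, on what has been measured and on what is new or still open speak of the compounds shown alone.

Measured compounds:
compound 1, `c1cc(-c2nccs2)c2c(c1)C(c1ncc[nH]1)CC2`: 426 nM
compound 2, `Cc1c(OCC2=NCCN2)ccc(Cl)c1NS(C)(=O)=O`: 25 nM

The study concerns a functional assay on CHO cells for agonist activity at Alpha-1A adrenergic receptor (Homo sapiens), read by FLIPR and calcium flux; on this read-out lower numbers stand for an effect already at smaller amounts and higher numbers for an effect only at larger amounts of compound. Within the data shown here, compound 1 stands at the higher of the two numbers measured so far; compound 2 gives a markedly lower number, and the gap between them lies beyond the usual scatter. The two share no single-point relationship, so only their two values can be compared.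

Compound 3, `Cc1oncc1-c1cccc2c1CCC2c1ncc[nH]1`, has not yet been measured. It differs from compound 1 in one place: 5-methyl-1,2-oxazol-4-yl in place of 1,3-thiazol-2-yl on an aromatic carbon. The core of compound 1 is kept, and the change concerns only the group on the aromatic carbon described. Among the measured compounds shown here, with no measured step of this kind available, the change is expected to produce at most a small shift in this assay, in no clear direction, and not beyond the scatter: the estimated step is a 1.1-fold lower number from compound 1 to compound 3 (0.03 log units; within the scatter). For compound 3 the estimate is 400 nM, with a range from 130 nM to 1300 nM.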

Compound 3, half-maximal effective concentration: 111 nM
For compound 3 the middle estimate is 3.6-fold (0.56 log units) above the measured one; measured number outside the range, below it.
By their numbers in this assay, from the lowest: compound 2; then compound 3; then compound 1.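

In this assay the group on this aromatic carbon proves not to be a neutral choice: 5-methyl-1,2-oxazol-4-yl in place of 1,3-thiazol-2-yl gives a 3.8-fold lower number from compound 1 to compound 3 (0.58 log units; beyond the scatter) with the core of compound 1 kept. Both groups are five-membered aromatic rings with 2 hetero atoms and the same counts of hydrogen-bond donors and acceptors, so those shared counts alone do not fix the read-out at this position. Nothing measured here accounts for the step.

Going by these compounds, the change swaps the ring and adds a methyl group in one move, so it remains open whether either alone carries the step. On these data alone, how a phenyl ring or a primary amine on this aromatic carbon would read in this assay also remains open.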